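Trifluoromethyl Replaces Fluoro: Compound 4 Expected to Improve

The source may report more compounds than this note shows. Statements on the series, on what has been measured and on what is new or still open speak of the compounds shown alone.

Three measured compounds share one core and differ only in the substituent on an aromatic carbon of the pendant ring. Compound 1 `Oc1nc2nonc2nc1Nc1ccc(S(F)(F)(F)(F)F)cc1` gives 3900 nM in an assay on mitochondria from L6 cells (Rattus norvegicus) for activation, with a stated time of 90 min; a lower number here means that less compound is needed, a higher number that more compound is needed for the effect. Compound 2 `CCCCCc1ccc(Nc2nc3nonc3nc2O)cc1` gives 2400 nM in this assay, and the step of a 1.6-fold lower number from compound 1 to compound 2 (0.21 log units; within the scatter). Compound 3 `Oc1nc2nonc2nc1Nc1ccc(F)cc1` gives 38600 nM in this assay and stands with the highest number of the three: the steps of a 9.9-fold higher number from compound 1 to compound 3 (1.00 log units; beyond the scatter) and a 16-fold higher number from compound 2 to compound 3 (1.21 log units; beyond the scatter) both run toward compound 3.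

Compound 4 `Oc1nc2nonc2nc1Nc1ccc(C(F)(F)F)cc1` differs from compound 3 as follows: trifluoromethyl in place of fluoro on an aromatic carbon. The two steps that bear on this are the ones ending at compound 3, both of which replaced a larger group by fluoro and gave clearly higher numbers. Compound 4 reverses that direction, though the trifluoromethyl entering carries fewer heavy atoms than either group removed in those steps. Compound 4 is therefore expected to give a lower number than compound 3, but by a smaller margin than those two steps, so the estimated step is a 4.8-fold lower number from compound 3 to compound 4 (0.68 log units; beyond the scatter). Compound 4 is estimated at 8000 nM in this assay, with a range from 3500 nM to 20000 nM.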

Compound 4, half-maximal effective concentration: 10400 nM
The estimate for compound 4 lay 1.3-fold (0.11 log units) below the measured number; measured number inside the range.
By their numbers in this assay, from the lowest: compounds 2 and 1 (each within the scatter of the next); then compound 4; then compound 3.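

In this assay, the change from fluoro to trifluoromethyl on this aromatic carbon gives a 3.7-fold lower number from compound 3 to compound 4 (0.57 log units; beyond the scatter) and shows that the number at this position can fall clearly with a group much smaller than pentyl or the sulfur-bearing group of compound 1. The fall is only partial, as the two larger groups still lie lower, with a 4.3-fold higher number from compound 2 to compound 4 (0.64 log units; beyond the scatter) and a 2.7-fold higher number from compound 1 to compound 4 (0.43 log units; beyond the scatter) both beyond the scatter; across these four compounds the number falls in steps from fluoro through trifluoromethyl to the two larger groups, although compounds 1 and 2 lie within the scatter of each other and so give that trend no order at its lower end. Nothing available here explains why this position responds in this way, and the four values describe the trend without accounting for it.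

The compounds shown leave open whether a longer chain than pentyl would take the number lower still or whether the trend levels off near the values of compounds 1 and 2. They also leave open how groups of another kind, such as an amine or a carboxylic acid, would behave at this same place on the ring.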